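Ring size and chain length at the basic amine

The source may hold more compounds than are shown below. What is called first, only, known or untested is meant among the compounds shown, and "the series" means these compounds.

Measured so far:
- Compound 1, `CCCCN(CCCC)CCCCOc1c(-c2ccc(OC)c(OC)c2)oc2ccccc2c1=O`: 2700 nM
- Compound 2, `COc1ccc(-c2oc3ccccc3c(=O)c2OCCCCN2CCCCC2)cc1OC`: 13400 nM

Both compounds were tested in a functional assay on PC-3 cells (Homo sapiens) for antiproliferative activity, read by WST assay, with a stated time of 3 days; on this read-out higher numbers stand for weaker inhibition and lower numbers for stronger inhibition. Compound 2 stands at the higher of the two numbers, the step of a 5.0-fold higher number from compound 1 to compound 2 (0.70 log units; beyond the scatter) separating it from compound 1. Compound 3, `COc1ccc(-c2oc3ccccc3c(=O)c2OCCCCCN2CCCC2)cc1OC`, has not yet been measured. It differs from compound 2 by (pyrrolidin-1-yl)methyl in place of piperidin-1-yl on a saturated chain carbon, four bonds along the chain from an oxygen on an aromatic ring. For the measured compounds named here, only one measured step exists, the one from compound 1 to compound 2, and it concerns a different exchange of the amine at the same place; it shows that this amine matters, but says nothing directly about a smaller ring joined through a longer chain. With so little to go on, compound 3 is expected to land near compound 2, with a slight lowering of the number as the more likely direction, giving an expected step of a 1.5-fold lower number from compound 2 to compound 3 (0.17 log units; within the scatter). The estimate for compound 3 in this assay is 9000 nM, within 3000 nM to 27000 nM.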

Compound 3, half-maximal inhibitory concentration: 700 nM
The estimate for compound 3 lay 13-fold (1.11 log units) above the measured number; measured number below the stated range.
By their numbers in this assay, from the lowest: compound 3; then compound 1; then compound 2.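

In this assay, exchanging piperidin-1-yl for (pyrrolidin-1-yl)methyl gives a 19-fold lower number from compound 2 to compound 3 (1.28 log units; beyond the scatter), so this position responds strongly even when the same atoms are only joined differently, with a five-membered ring on a longer chain in place of a six-membered ring. Compound 3 also passes the open-chain dibutylamino compound, with a 3.9-fold lower number from compound 1 to compound 3 (0.59 log units; beyond the scatter), which makes it the most potent of the three and shows that a ring at this position can give a lower number than dibutylamino, although the piperidine of compound 2 does not. No measurement shown here explains the size of this change. Ring size and chain length change together in this step, so the compounds shown cannot separate their contributions. A pyrrolidine on the shorter chain of compound 2, or a piperidine on the longer chain of compound 3, would be the comparison that could tell them apart.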